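Small chlorinated hydrazone replaces nitrophenyl formamidine in weak series

A few compounds are considered here, and "the series" means these few. Any claim that something is new, unique, unknown or untested is made for them only; others in the source may bear on it.

The study reports three compounds built on one shared core and measured in a functional assay on HeLa cells (Homo sapiens) for inhibition, read by MTT assay, with a stated time of 48 h; on this read-out higher numbers stand for weaker inhibition and lower numbers for stronger inhibition. Compound 1 `CCOC(=O)C1=C(N/N=C(/Br)c2ccccc2)Nc2[nH]nc(C)c2C1c1ccc(N(C)C)cc1` gives 75700 nM. Compound 2 `CCOC(=O)C1=C(NN=C(C(C)=O)C(C)=O)Nc2[nH]nc(C)c2C1c1ccc(N(C)C)cc1` gives 17000 nM. Compound 3 `CCOC(=O)C1=C(N/C=N/c2ccc([N+](=O)[O-])cc2)Nc2[nH]nc(C)c2C1c1ccc(N(C)C)cc1` gives 57800 nM. Among these three numbers compound 3 stands second highest; its nearest neighbour is compound 1, with a 1.3-fold lower number from compound 1 to compound 3 (0.12 log units; within the scatter), and its furthest is compound 2, with a 3.4-fold higher number from compound 2 to compound 3 (0.53 log units; beyond the scatter).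

Compound 4 `CCOC(=O)C1=C(N/N=C(/Cl)C#N)Nc2[nH]nc(C)c2C1c1ccc(N(C)C)cc1` has not yet been measured. It differs from compound 3 by a group of 5 heavy atoms (2 carbon, 2 nitrogen, 1 chlorine; no ring) in place of a group of 11 heavy atoms (7 carbon, 2 nitrogen, 2 oxygen; one six-membered aromatic ring of carbon only), on an amine nitrogen. Among the compounds with values here, two measured steps bear on this change. Replacing a ring-bearing group on the amine nitrogen with one lacking a ring gave a 4.5-fold lower number from compound 1 to compound 2 (0.65 log units; beyond the scatter), and the reverse direction gave a 3.4-fold higher number from compound 2 to compound 3 (0.53 log units; beyond the scatter). Compound 4 also carries a group without a ring on that nitrogen, so a modest step towards a lower number is expected, a 1.9-fold lower number from compound 3 to compound 4 (0.28 log units; within the scatter). Compound 4 is therefore estimated at 30000 nM, with a range from 10000 nM to 90000 nM.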

Compound 4, half-maximal inhibitory concentration: 26200 nM
The estimate for compound 4 lay 1.1-fold (0.06 log units) above the measured number; measured number inside the range.
By their numbers in this assay, from the lowest: compounds 2 and 4 (each within the scatter of the next); then compounds 3 and 1 (each within the scatter of the next).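

In this assay, the group of 5 heavy atoms on the amine nitrogen gives a 2.2-fold lower number from compound 3 to compound 4 (0.34 log units; beyond the scatter) and a 2.9-fold lower number from compound 1 to compound 4 (0.46 log units; beyond the scatter). This makes compound 4 the second ring-free group to sit apart from both ring-bearing compounds, and no compound shown goes against that split. The two ring-free groups share no more than the absence of a ring, yet they are not separated, with a 1.5-fold higher number from compound 2 to compound 4 (0.19 log units; within the scatter). No measured evidence accounts for this result.

Each step swaps a whole group, so the shown compounds do not separate the loss of the ring from the other differences, such as the chlorine or the triple bond. On these data alone, it also stays open whether a simple ethyl chain or a carboxylic acid on this nitrogen would fall with compound 2 and compound 4.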